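Compound 3: a trifluoromethyl isomer awaiting measurement

The compounds below may be only part of what the source reports. "The series", "measured", "known", "first", "only" and "open" are said of these compounds alone.

Compound 1 `COc1cc(NC(C)CCCNC(=O)Nc2cccc(F)c2)c2ncccc2c1`: 27000 nM
Compound 2 `COc1cc(NC(C)CCCNC(=O)Nc2ccc(C(F)(F)F)cc2)c2ncccc2c1`: 22000 nM

In a functional assay on SW-620 cells (Homo sapiens) for inhibition, read by MTT assay, with a stated time of 72 h (on this read-out lower numbers stand for stronger inhibition and higher numbers for weaker inhibition), compound 2 gives 22000 nM, which lies within the scatter of compound 1. The next compound, compound 3 `COc1cc(NC(C)CCCNC(=O)Nc2cccc(C(F)(F)F)c2)c2ncccc2c1`, has not yet been measured. It differs from compound 2 in one group 3-(trifluoromethyl)phenyl in place of 4-(trifluoromethyl)phenyl on an amide-type nitrogen. For the measured compounds named here, no measured pair isolates this change. The closest evidence is a single step, a 1.2-fold lower number from compound 1 to compound 2 (0.09 log units; within the scatter), in which 4-(trifluoromethyl)phenyl replaced 3-fluorophenyl on that same kind of nitrogen. Going by the values given here, with only this step as a guide, no change beyond the scatter is expected in this assay. The expected step is no change at the digits printed from compound 2 to compound 3 (within the scatter). Compound 3 is estimated at 22000 nM, with an expected range from 11000 nM to 45000 nM.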

Compound 3, half-maximal inhibitory concentration: 22000 nM
Compound 3: middle estimate and measured number agree at the digits printed, and the stated range covers the measured number.
By their numbers in this assay, from the lowest: compounds 2, 3 and 1 (each within the scatter of the next).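

In this assay, 3-(trifluoromethyl)phenyl in place of 4-(trifluoromethyl)phenyl on the amide-type nitrogen gives no change at the digits printed from compound 2 to compound 3 (within the scatter), so this pair isolates the place of the trifluoromethyl group on the phenyl ring, and that place makes no difference beyond the scatter. Trifluoromethyl in place of fluoro on an aromatic carbon gives a 1.2-fold lower number from compound 1 to compound 3 (0.09 log units; within the scatter), which separates the exchange of these two groups from the shift in place that the earlier step combined with it. No evidence is available to explain why these changes leave the number within the scatter.

The compounds shown leave open whether an amine or a carboxylic acid on the phenyl ring, or a longer chain in place of the one carrying the amide-type nitrogen, would move the number beyond the scatter in this assay. They also leave open how these compounds would behave in other cells.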